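Thiourea series: cytotoxicity notes, methyl to fluoro

This account rests on a few compounds, and the source may have more. Where it says the series, first, only, none or still open, it means among the compounds named here.

Measured so far in an ADME assay on MDBK cells (Bos taurus) for cytotoxicity, read by MTT assay, with a stated time of 96 h; a higher number here means that more compound is tolerated, a lower number that less compound is tolerated:
compound 1 `C=C(C)CNC(=S)Nc1cccc(C(F)(F)F)c1` gives > 100000 nM
compound 2 `Cc1ccc(NC(=S)Nc2cccc(C(F)(F)F)c2)cc1Cl` gives 10000 nM
compound 3 `O=[N+]([O-])c1ccc(NC(=S)Nc2cccc(C(F)(F)F)c2)cc1` gives 10000 nM

The value of compound 1 is a limit of the assay and not a number (the limit of > 100000 nM in this assay, at which 1 of the 3 values shown sits). Compound 2 stands level with compound 3 at the digits given, within the scatter, so no order between the two can be read. Among the measured compounds shown here, no pair of measured compounds differs in a single place, so no measured step is available to lean on.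

Compound 4 `Fc1ccc(NC(=S)Nc2cccc(C(F)(F)F)c2)cc1Cl` has not yet been tested in this assay. Against compound 2 the change is fluoro in place of methyl on an aromatic carbon. The group that leaves and the group that enters are each a single heavy atom, with no change in donors, acceptors or charge.

The step from compound 2 to compound 4 is expected to be no larger than the scatter, in either direction: no change at the digits printed from compound 2 to compound 4 (within the scatter). Compound 4 is therefore expected at about 10000 nM, with a range of 3000 nM to 30000 nM.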

Compound 4, half-maximal cytotoxic concentration: 11000 nM
The estimate for compound 4 lay 1.1-fold (0.04 log units) below the measured number; the range from low to high includes it.
By their numbers in this assay, from the lowest: compounds 2, 3 and 4 (each within the scatter of the next). At a limit, above all of these: compound 1.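

In this assay the series now has its first step at a single place, a 1.1-fold higher number from compound 2 to compound 4 (0.04 log units; within the scatter), for fluoro in place of methyl on an aromatic carbon ortho to a chloro group and para to a large group. Among the compounds shown here, at this position and on this core, the two single-atom groups therefore give values that cannot be told apart, which the earlier compounds, none differing from another in one place, could not show. Nothing at hand bears on why the two groups read alike.

From the compounds shown here alone, whether this holds for bigger groups at the same carbon stays open: an amine, a carboxylic acid or a longer chain there would test it. Also open, going by these compounds, is what a methoxy group would do in place of the chloro group.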